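Swapping the benzoxazole for imidazole on the sulfur

The source may hold more compounds than are shown below. What is called first, only, known or untested is meant among the compounds shown, and "the series" means these compounds.

Compounds measured so far:
compound 1 `Cc1ccc2oc(SCC(=O)Nc3ccc(-c4nc(-c5ccccc5)c(-c5ccccc5)n4C)cc3)nc2c1` 24.6%
compound 2 `Cn1cnnc1SCC(=O)Nc1ccc(-c2nc(-c3ccccc3)c(-c3ccccc3)n2C)cc1` 59.2%

In a functional assay on MCF7 cells (Homo sapiens) for cytotoxicity, read by MTT assay, with a stated time of 24 h, tested at 6.4 ug/mL (on this read-out lower numbers stand for a weaker effect and higher numbers for a stronger effect at the one concentration tested), compound 1 gives the lowest of the two numbers; its nearest neighbour is compound 2, reached by a number 34.6 percentage points higher from compound 1 to compound 2 (beyond the scatter). Compound 3 `Cn1ccnc1SCC(=O)Nc1ccc(-c2nc(-c3ccccc3)c(-c3ccccc3)n2C)cc1` is not yet measured. It differs from compound 1 in one place: 1-methyl-1H-imidazol-2-yl in place of 5-methyl-1,3-benzoxazol-2-yl on a sulfur. Going by the values given here, the only measured step that bears on this change is the one from compound 1 to compound 2, where another small five-membered ring replaced the same group on the sulfur, and it was large and upward. A step of similar direction, though perhaps smaller, is therefore expected in this assay, a number 25.4 percentage points higher from compound 1 to compound 3 (beyond the scatter). Compound 3 is estimated at 50%, within 30% to 70%.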

Compound 3, a percentage reported as activity, at one concentration (the size of the read-out at that concentration, not a potency): 27.2%
Compound 3: middle estimate off by 22.8 percentage points, on the high side; the measured number lies below the stated range.
By their numbers in this assay, from the lowest: compounds 1 and 3 (each within the scatter of the next); then compound 2.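

In this assay, the 1-methyl-1H-imidazol-2-yl group on the sulfur gives a number 2.6 percentage points higher from compound 1 to compound 3 (within the scatter), so the smaller ring does not separate itself from the 5-methyl-1,3-benzoxazol-2-yl group. The same exchange read against the triazole gives a number 32 percentage points lower from compound 2 to compound 3 (beyond the scatter), which shows that a five-membered ring on this sulfur is not enough to reach the number of compound 2. Nothing available explains this difference between the two rings.

From the compounds shown here alone, it remains open whether the high number of compound 2 is specific to its 4-methyl-4H-1,2,4-triazol-3-yl group. An amine on that ring, or an ethyl group in place of its methyl, could test this.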